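Trihydroxyphenyl in place of 2-methoxyphenyl on growth inhibition

A few compounds are considered here, and "the series" means these few. Any claim that something is new, unique, unknown or untested is made for them only; others in the source may bear on it.

In a functional assay on DU-145 cells (Homo sapiens) for inhibition, read by trypan blue exclusion, with a stated time of 96 h (on this read-out lower numbers stand for stronger inhibition of growth and higher numbers for weaker inhibition of growth), compound 3 `COc1ccccc1/C=C(\C(=O)c1ccc(Cl)cc1)S(=O)(=O)Cc1ccc(C)cc1` gives 10000 nM and stands level with compound 1 `Cc1ccc(CS(=O)(=O)/C(=C/c2cc(C)cc(C)c2)C(=O)c2ccc(Cl)cc2)cc1` at 10000 nM as the lowest of three numbers, while compound 2 `Cc1ccc(CS(=O)(=O)/C(=C/c2c[nH]c3ccccc23)C(=O)c2ccc(Cl)cc2)cc1` gives 25000 nM and sits higher. Compound 4 `Cc1ccc(CS(=O)(=O)/C(=C/c2c(O)cc(O)cc2O)C(=O)c2ccc(Cl)cc2)cc1` carries 2,4,6-trihydroxyphenyl in place of 2-methoxyphenyl on a double-bonded chain carbon bound to a double-bonded chain carbon. Three measured swaps at this place bear on it: no change at the digits printed from compound 1 to compound 3 (within the scatter) within the scatter, and a 2.5-fold higher number from compound 1 to compound 2 (0.40 log units; beyond the scatter) and a 2.5-fold lower number from compound 2 to compound 3 (0.40 log units; beyond the scatter) as modest steps. Going by the values given here, no measured compound carries the incoming group, so the direction stays open. The expected result is a 1.2-fold higher number from compound 3 to compound 4 (0.08 log units; within the scatter) and thus no step beyond the scatter in this assay overall. For compound 4 the estimated value is 12000 nM (range 3000 nM to 40000 nM).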

Compound 4, concentration for 50% growth inhibition: > 100000 nM
Compound 4 was reported as a limit; the forecaster's own chance of this, stated with the estimate: 15%; at least 8.3-fold (0.92 log units) between middle value and limit.
By their numbers in this assay, from the lowest: compounds 1 and 3 (each within the scatter of the next); then compound 2. At a limit, above all of these: compound 4.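

In this assay compound 4 is reported only as a limit: the limit of > 100000 nM in this assay, at which 1 of the 4 values shown sits. Placing 2,4,6-trihydroxyphenyl on this double-bonded chain carbon gives an at least 10-fold higher number from compound 3 to compound 4 (1.00 log units; beyond the scatter), an at least 10-fold higher number from compound 1 to compound 4 (1.00 log units; beyond the scatter) and an at least 4.0-fold higher number from compound 2 to compound 4 (0.60 log units; beyond the scatter). The three earlier groups had shown only modest steps at most, so this position does not accept every substituted ring equally. From the compounds shown here alone, whether 2-hydroxyphenyl or 2,4,6-trimethoxyphenyl would keep the number near that of compound 3 stays open. Going by these compounds, how far the true number of compound 4 lies past its limit also stays open.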